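This account rests on a few compounds, and the source may have more. Where it says the series, first, only, none or still open, it means among the compounds named here.

Measured so far in a functional assay on PC-3 cells (Homo sapiens) for antiproliferative activity, read by CCK-8 assay, with a stated time of 6 days; on this read-out lower numbers stand for stronger inhibition and higher numbers for weaker inhibition:
- Compound 1 `CCN(c1ccc(C#N)c(Cl)c1)c1cc(-c2ccncc2)ccc1C`: 3580 nM
- Compound 2 `N#Cc1ccc(N2CCc3cc(-c4cnc5ccccc5c4)ccc32)cc1C(F)(F)F`: "not determined" (no result reported)
- Compound 3 `N#Cc1ccc(N2CCCc3c(-c4ccncc4)cccc32)cc1C(F)(F)F`: 28700 nM

Only two of these compounds have numbers, and compound 1 holds the lower one, so it is the stronger inhibitor of that pair. Compound 3, at 28700 nM, stands higher by more than the usual scatter. Compound 4 `CCN(c1ccc(C#N)c(Cl)c1)c1cc(-c2ccc(F)nc2)ccc1C` keeps the core of compound 1 and differs in one place, 6-fluoropyridin-3-yl in place of pyridin-4-yl on an aromatic carbon. Among the compounds with values here, no measured pair shows this swap, so no step beyond the scatter is expected in this assay. The estimated change is a 1.2-fold lower number from compound 1 to compound 4 (0.08 log units; within the scatter). For compound 4 the expected value is 3000 nM, within an estimated range of 800 nM to 12000 nM.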

Compound 4, half-maximal inhibitory concentration: > 30000 nM
Compound 4: no number, only a limit; the forecaster's own chance of this, stated with the estimate: 10%; at least 10-fold (1.00 log units) between middle value and limit.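

In this assay, putting 6-fluoropyridin-3-yl in place of pyridin-4-yl is not a neutral swap, as it gives an at least 8.3-fold higher number from compound 1 to compound 4 (0.92 log units; beyond the scatter). Compound 4 has only a limit, not a number: the limit of > 30000 nM in this assay, at which 1 of the 4 values shown sits. Within the data shown here, this is the first pair that differs in one place, and it shows that activity depends on the ring attached at this aromatic carbon.

The step cannot be divided between the fluorine and the change from pyridin-4-yl to a pyridin-3-yl attachment. From the compounds shown here alone, how an amine or a carboxylic acid on this ring would read also remains open.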